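Swapping the Aryl Group on the Ring Nitrogen

The compounds below may be only part of what the source reports. "The series", "measured", "known", "first", "only" and "open" are said of these compounds alone.

Three compounds sharing one core have been compared in a functional assay on A549 cells (Homo sapiens) for antiproliferative activity, read by MTT assay, with a stated time of 72 h; a higher number here means a weaker inhibitor, a lower number a stronger inhibitor. Compound 1 `Cn1ccc2c(Oc3ccc(NC(=O)c4cc5cccnc5n(-c5ccc(C(F)(F)F)cc5Cl)c4=O)cc3)ccnc21` gives 8250 nM. Compound 2 `COc1ccc(-n2c(=O)c(C(=O)Nc3ccc(Oc4ccnc5c4ccn5C)c(F)c3)cc3cccnc32)cc1` gives 2750 nM. Compound 3 `Cn1ccc2c(Oc3ccc(NC(=O)c4cc5cccnc5n(-c5ccc(F)c(Cl)c5)c4=O)cc3F)ccnc21` gives 3560 nM, which places it second highest of the three, close to compound 2 and furthest from compound 1. Among the compounds with values here, the only measured step touching the group on the aromatic nitrogen, a 1.3-fold higher number from compound 2 to compound 3 (0.11 log units; within the scatter), stayed within the scatter.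

Compound 4 `Cn1ccc2c(Oc3ccc(NC(=O)c4cc5cccnc5n(-c5ccc(C(F)(F)F)cc5Cl)c4=O)cc3F)ccnc21` has not yet been measured. It differs from compound 3 in one place: 2-chloro-4-(trifluoromethyl)phenyl in place of 3-chloro-4-fluorophenyl on an aromatic nitrogen. Within the data shown here, no measured step covers this exact exchange. The nearest guidance is that compound 1 carries the same 2-chloro-4-(trifluoromethyl)phenyl group on a core that lacks the fluorine present in compound 3, and compound 1 gives 8250 nM, the highest number of the three. Among the measured compounds shown here, the step from compound 3 to compound 4 is therefore expected to raise the number somewhat, a 1.7-fold higher number from compound 3 to compound 4 (0.23 log units; within the scatter), though the one measured exchange of this group stayed within the scatter, so the expectation is loose. Compound 4 is estimated at 6000 nM in this assay, with a range from 2700 nM to 13000 nM.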

Compound 4, half-maximal inhibitory concentration: 3530 nM
Compound 4: middle estimate off by 1.7-fold (0.23 log units), on the high side; the measured number falls inside the stated range.
By their numbers in this assay, from the lowest: compounds 2, 4 and 3 (each within the scatter of the next); then compound 1.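

With 2-chloro-4-(trifluoromethyl)phenyl in place of 3-chloro-4-fluorophenyl on the aromatic nitrogen, this assay shows a 1.0-fold lower number from compound 3 to compound 4 (0.00 log units; within the scatter) and so gives no sign that this exchange matters, even though the entering group has more heavy atoms. On the fluorinated core, the result extends to a third aryl group: replacing 4-methoxyphenyl gives a 1.3-fold higher number from compound 2 to compound 4 (0.11 log units; within the scatter) and also leaves no readable difference, so the three aryl groups on this core cannot be told apart in this assay. The clearest difference instead lies elsewhere on the molecule: fluoro in place of hydrogen on an aromatic carbon gives a 2.3-fold lower number from compound 1 to compound 4 (0.37 log units; beyond the scatter) and is the only step among these compounds that lies beyond the scatter, which shows that the high number of compound 1 does not follow from its aryl group alone.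

No supporting measurement offers an explanation for either outcome. Still open, on these data alone, are whether the fluorine step would hold with 4-methoxyphenyl or 3-chloro-4-fluorophenyl on the aromatic nitrogen, and whether a pyridine ring or a phenyl ring bearing an amine at that position would stay in the same range.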